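The source may report more compounds than this note shows. Statements on the series, on what has been measured and on what is new or still open speak of the compounds shown alone.

Compound 1 `O=c1ccoc2cc(OCc3cn(Cc4ccc(Cl)cc4)nn3)ccc12` is the starting point of this account. In a functional assay on MDA-MB-231 cells (Homo sapiens) for cytotoxicity, read by MTT assay, with a stated time of 48 h (on this read-out lower numbers stand for stronger inhibition and higher numbers for weaker inhibition), compound 1 gives > 100000 nM, which is a limit of the assay and not a number. Compound 2 `O=c1ccoc2cc(OCc3cn(Cc4cccc(Br)c4)nn3)ccc12` gives > 100000 nM in this assay, again only a limit. Compound 3 `O=c1ccoc2cc(OCc3cn(Cc4cccc(F)c4)nn3)ccc12` gives > 100000 nM in this assay, also a limit. Compound 1 therefore stands only at a limit on the numbers shown, as do the other two values, and all three sit at the limit of > 100000 nM in this assay, at which 3 of the 3 values shown sit. The measured steps are a step that the two limits leave unreadable from compound 1 to compound 2, a step that the two limits leave unreadable from compound 1 to compound 3 and a step that the two limits leave unreadable from compound 2 to compound 3; none of them has a readable size, so they set no direction. Compound 4 `N#Cc1cccc(Cn2cc(COc3ccc4c(=O)ccoc4c3)nn2)c1` has not yet been measured. It differs from compound 1 as follows: 3-cyanophenyl in place of 4-chlorophenyl on a saturated chain carbon bound to an aromatic nitrogen. Within the data shown here, the steps that bear on it are those in which one substituted benzyl group replaces another on the same carbon, and each of them is unreadable because of the limit of > 100000 nM in this assay, at which 3 of the 3 values shown sit. No step beyond the scatter is therefore expected in this assay, and the likeliest outcome is again a limit. Compound 4 is estimated to give 150000 nM, with a range from 40000 nM to 600000 nM. This estimate means an expected step that the limit leaves unreadable from compound 1 to compound 4.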

Compound 4, half-maximal inhibitory concentration: > 100000 nM
Compound 4 was reported as a limit; the forecaster's own chance of this, stated with the estimate: 85%; the middle value lies beyond the limit too.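

Compound 4 ends at a limit of the assay, as do compound 1, compound 2 and compound 3, so its steps to those three compounds cannot be read: the limit of > 100000 nM in this assay, at which 4 of the 4 values shown sit.

The compounds shown leave open whether any substituted benzyl group on the shared core would give a readable value in this assay.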